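This account rests on a few compounds, and the source may have more. Where it says the series, first, only, none or still open, it means among the compounds named here.

Compound 1 `COc1ccc(/C=C/C(=O)Nc2cc3c(Nc4ccc(F)c(Cl)c4)ncnc3cc2OC)c(OC)c1`: 33300 nM
Compound 2 `COc1cc(/C=C/C(=O)Nc2cc3c(Nc4ccc(F)c(Cl)c4)ncnc3cc2O[C@H]2CCOC2)cc(OC)c1O`: 27000 nM

In a functional assay on A549 cells (Homo sapiens) for cytotoxicity, read by MTT assay, with a stated time of 72 h (on this read-out higher numbers stand for weaker inhibition and lower numbers for stronger inhibition), compound 1 gives 33300 nM, the higher of the two numbers at hand. Compound 2 gives 27000 nM in this assay, and the gap between the two lies within the scatter, so the two compounds stand level rather than in any order. The unmeasured compound 3 `COc1cc(/C=C/C(=O)Nc2cc3c(Nc4ccc(F)c(Cl)c4)ncnc3cc2OC)cc(OC)c1` keeps the core of compound 1 with the same atoms joined differently: 3,5-dimethoxyphenyl in place of 2,4-dimethoxyphenyl on a double-bonded chain carbon bound to a double-bonded chain carbon. Among the compounds with values here, no step between measured compounds is available to show what exchanging one dimethoxyphenyl for the other does, and compound 2 differs from compound 1 in more than that group, so its value serves only as a second point near the same level. With nothing in the data pointing to a shift in either direction, the step is expected to be small and not beyond the scatter: a 1.1-fold lower number from compound 1 to compound 3 (0.05 log units; within the scatter). Compound 3 is therefore estimated at 30000 nM in this assay, with a range from 12000 nM to 75000 nM.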

Compound 3, half-maximal inhibitory concentration: "not active" (no number reported)
For compound 3 the study gives words and no number; there is nothing to compare the estimate with.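

In this assay, within the data shown here, compound 3 is reported only in words, as not active, so no step from compound 1 to compound 3 can be read. Nothing shown bears on this result. The compounds shown leave open how far exchanging 2,4-dimethoxyphenyl for 3,5-dimethoxyphenyl moves the number on this read-out.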